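The source may hold more compounds than are shown below. What is called first, only, known or untested is meant among the compounds shown, and "the series" means these compounds.

Measured compounds in a functional assay on MCF7 cells (Homo sapiens) for cytotoxicity, read by sulforhodamine B assay, with a stated time of 48 h; a lower number here means a stronger inhibitor, a higher number a weaker inhibitor:
- compound 1 `COc1ccc(/C=C2\C(=O)N(Cc3cn([C@@H]4O[C@H](COC(C)=O)[C@@H](OC(C)=O)[C@H](OC(C)=O)[C@H]4OC(C)=O)nn3)c3ccccc32)cc1OC` gives 23500 nM
- compound 2 `CC(=O)OC[C@H]1O[C@@H](n2cc(CN3C(=O)/C(=C\c4ccc(N(C)C)cc4)c4ccccc43)nn2)[C@H](OC(C)=O)[C@@H](OC(C)=O)[C@@H]1OC(C)=O` gives 29800 nM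
- compound 3 `CC(=O)OC[C@H]1O[C@@H](n2cc(CN3C(=O)/C(=C\c4cccs4)c4ccccc43)nn2)[C@H](OC(C)=O)[C@@H](OC(C)=O)[C@@H]1OC(C)=O` gives 36100 nM

Compound 3 holds the highest of the three numbers, yet its distances to the others are within the scatter: a 1.2-fold higher number from compound 2 to compound 3 (0.08 log units; within the scatter) and a 1.5-fold higher number from compound 1 to compound 3 (0.19 log units; within the scatter). Compound 4 `CC(=O)OC[C@H]1O[C@@H](n2cc(CN3C(=O)/C(=C\c4ccco4)c4ccccc43)nn2)[C@H](OC(C)=O)[C@@H](OC(C)=O)[C@@H]1OC(C)=O` differs from compound 3 by furan-2-yl in place of thiophen-2-yl on a double-bonded chain carbon bound to a double-bonded ring carbon. The steps bearing on this change are the three exchanges at the same place, a 1.3-fold higher number from compound 1 to compound 2 (0.10 log units; within the scatter), a 1.5-fold higher number from compound 1 to compound 3 (0.19 log units; within the scatter) and a 1.2-fold higher number from compound 2 to compound 3 (0.08 log units; within the scatter), none beyond the scatter. The expected step is therefore a 1.0-fold lower number from compound 3 to compound 4 (0.01 log units; within the scatter), with no movement beyond the scatter in this assay. Compound 4 is estimated at 35000 nM, with a range of 17000 nM to 72000 nM.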

Compound 4, half-maximal inhibitory concentration: 38200 nM
For compound 4 the middle estimate is 1.1-fold (0.04 log units) below the measured one; the range from low to high includes it.
By their numbers in this assay, from the lowest: compounds 1, 2, 3 and 4 (each within the scatter of the next).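

With furan-2-yl in place of thiophen-2-yl, a 1.1-fold higher number from compound 3 to compound 4 (0.02 log units; within the scatter) stays within the scatter in this assay, so exchanging one five-membered aromatic ring for the other at this place shows no measurable effect. The wider exchanges, a 1.3-fold higher number from compound 2 to compound 4 (0.11 log units; within the scatter) and a 1.6-fold higher number from compound 1 to compound 4 (0.21 log units; within the scatter), also stay within the scatter, leaving all four groups on the double-bonded chain carbon indistinguishable in this series. No measurement available offers an explanation for this flat result.

On these data alone, what an amine or a carboxylic acid at this place would do in this assay remains open. So does the effect of any change elsewhere on the shared core.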